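Dropping the Urea: Expected Cytotoxicity of a Benzyl Ester

This account rests on a few compounds, and the source may have more. Where it says the series, first, only, none or still open, it means among the compounds named here.

Measured compounds:
compound 1 `Cc1cn([C@@H]2O[C@H](CO[Si](C)(C)C(C)(C)C)[C@@]3(OS(=O)(=O)C=C3NCC(=O)C(=O)N3CCC3)[C@H]2O[Si](C)(C)C(C)(C)C)c(=O)n(C)c1=O` gives 65000 nM
compound 2 `COC(=O)CNC1=CS(=O)(=O)O[C@@]12[C@@H](CO[Si](C)(C)C(C)(C)C)O[C@@H](n1cc(C)c(=O)n(C)c1=O)[C@@H]2O[Si](C)(C)C(C)(C)C` gives >= 400000 nM, a limit of the assay
compound 3 `CCOC(=O)CNC(=O)NC1=CS(=O)(=O)O[C@@]12[C@@H](CO[Si](C)(C)C(C)(C)C)O[C@@H](n1cc(C)c(=O)n(C)c1=O)[C@@H]2O[Si](C)(C)C(C)(C)C` gives 16000 nM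

In a functional assay on HEL cells (Homo sapiens) for cytotoxicity, read by microscopy (on this read-out lower numbers stand for higher toxicity in this test and higher numbers for lower toxicity in this test), compound 3 has the lowest of the two real numbers; the nearest is compound 1, with a 4.1-fold lower number from compound 1 to compound 3 (0.61 log units; beyond the scatter). Compound 4 `Cc1cn([C@@H]2O[C@H](CO[Si](C)(C)C(C)(C)C)[C@@]3(OS(=O)(=O)C=C3NCC(=O)OCc3ccccc3)[C@H]2O[Si](C)(C)C(C)(C)C)c(=O)n(C)c1=O` differs from compound 3 by (benzyloxycarbonyl)methyl in place of ((ethoxycarbonyl)methyl)carbamoyl on an amine nitrogen. The closest guide is compound 2, which carries a (methoxycarbonyl)methyl group on the same amine nitrogen, without the carbamoyl link, and the step of an at least 25-fold lower number from compound 2 to compound 3 (1.39 log units; beyond the scatter) was large. Removing that carbamoyl link in compound 4 is therefore expected to raise the number substantially, a 13-fold higher number from compound 3 to compound 4 (1.10 log units; beyond the scatter), and a limit such as the limit of >= 400000 nM in this assay, at which 1 of the 3 values shown sits, is possible. Compound 4 is expected to give about 200000 nM, between 50000 nM and 400000 nM.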

Compound 4, minimum cytotoxic concentration: >= 400000 nM
Compound 4: a limit, no number (the forecaster's own chance of this, stated with the estimate: 45%); middle value at least 2.0-fold (0.30 log units) away from the limit.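

In this assay, the (benzyloxycarbonyl)methyl group on the amine nitrogen gives an at least 25-fold higher number from compound 3 to compound 4 (1.39 log units; beyond the scatter). Against the side chain ending in (azetidin-1-yl)carbonyl, it gives an at least 6.1-fold higher number from compound 1 to compound 4 (0.78 log units; beyond the scatter), so adding a benzene ring to the ester does not restore a measurable toxicity at this position. The step between the methyl and benzyl esters cannot be read, since both compounds rest at the same limit: the limit of >= 400000 nM in this assay, at which 2 of the 4 values shown sit.

Still open, from the compounds shown here alone, is whether the carbamoyl link alone drives the toxicity of compound 3, which a benzyl ester kept on that link would test. Going by these compounds, a free carboxylic acid in place of the ester also remains unexplored here.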